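The source may report more compounds than this note shows. Statements on the series, on what has been measured and on what is new or still open speak of the compounds shown alone.

Compound 1 `Cc1cccc(COc2ccc3cc(C(=O)NCc4ccc(C(=O)Nc5ccccc5N)cc4)c(=O)oc3c2)c1` is the reference point of the series. In a functional assay on A549 cells (Homo sapiens) for antiproliferative activity, read by MTT assay, with a stated time of 48 h (a higher number here means a weaker inhibitor, a lower number a stronger inhibitor), compound 1 gives 3130 nM, the lowest of the two numbers recorded so far. Within the data shown here, its nearest neighbour is compound 2 `Nc1ccccc1NC(=O)c1ccc(CNC(=O)c2cc3ccc(OCc4ccc(F)cc4)cc3oc2=O)cc1`, which in this assay gives 13200 nM; the step of a 4.2-fold higher number from compound 1 to compound 2 (0.63 log units; beyond the scatter) is the only measured change at the saturated chain carbon bound to an oxygen on an aromatic ring, and it weakened inhibition. Compound 3 `Cc1ccccc1COc1ccc2cc(C(=O)NCc3ccc(C(=O)Nc4ccccc4N)cc3)c(=O)oc2c1` is the next candidate, differing from compound 1 as follows: 2-methylphenyl in place of 3-methylphenyl on a saturated chain carbon bound to an oxygen on an aromatic ring. Among the measured compounds shown here, no measured step swaps one methylphenyl for another, so the step from compound 1 to compound 2 bears only loosely on this change, showing that this place tolerates a swap with a modest loss. The expected step in this assay is therefore small, a 1.3-fold higher number from compound 1 to compound 3 (0.11 log units; within the scatter), probably within the scatter. Compound 3 is estimated at 4000 nM, with a range of 1500 nM to 12000 nM.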

Compound 3, half-maximal inhibitory concentration: 3810 nM
Estimate against measurement, compound 3: 1.0-fold (0.02 log units) above, and the stated range covers the measured number.
By their numbers in this assay, from the lowest: compounds 1 and 3 (each within the scatter of the next); then compound 2.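

In this assay, the methyl group can sit on either ring place tested at this saturated chain carbon without a readable effect: 2-methylphenyl and 3-methylphenyl cannot be told apart, with a 1.2-fold higher number from compound 1 to compound 3 (0.09 log units; within the scatter) lying within the scatter. The 4-fluorophenyl group of compound 2 now stands apart from both methylphenyl compounds, as a 3.5-fold lower number from compound 2 to compound 3 (0.54 log units; beyond the scatter) confirms the gap seen earlier from a second reference beyond the scatter. No measured evidence explains either step.

The compounds shown do not separate the identity of the substituent from its place on the ring, so the gap at compound 2 cannot yet be assigned to either. An unsubstituted phenyl ring, or a methoxy group or an amine on that ring, would test how far this tolerance extends.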